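Swapping a Thiazole for an Oxazole: Expected Cytotoxicity

The source may report more compounds than this note shows. Statements on the series, on what has been measured and on what is new or still open speak of the compounds shown alone.

Compound 1 `CCCCNc1nc(N)nc2ccn(Cc3ccccc3)c12` was tested in an ADME assay on HEK293 cells (Homo sapiens) for cytotoxicity, read by ATP content, with a stated time of 6 h; on this read-out lower numbers stand for higher toxicity in this test and higher numbers for lower toxicity in this test. In this assay compound 1 gives > 24000 nM, which is a limit of the assay rather than a measured number. Compound 2 `Cc1nc(CNc2nc(N)nc3ccn(Cc4ccccn4)c23)cs1` shares the same core with a different group on the saturated chain carbon. In this assay compound 2 gives > 24000 nM, again only a limit of the assay and not a number. So compound 2 stands where every value so far stands: at the limit, with no number to rank it.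

Compound 3 `Cc1cc(CNc2nc(N)nc3ccn(Cc4ccccn4)c23)on1` has not been measured. It differs from compound 2 as follows: 3-methyl-1,2-oxazol-5-yl in place of 2-methyl-1,3-thiazol-4-yl on a saturated chain carbon bound to a nitrogen on an aromatic ring. For the measured compounds named here, no measured step between two compounds exists here, so the size of this change can only be guessed. The step from compound 2 to compound 3 is expected to be a step that the limit leaves unreadable from compound 2 to compound 3, that is, no change beyond the scatter, because of the limit of > 24000 nM in this assay, at which 2 of the 2 values shown sit. Compound 3 is therefore expected to give about 30000 nM, within 12000 nM to 70000 nM, most likely again as a limit.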

Compound 3, half-maximal cytotoxic concentration: > 24000 nM
Compound 3: a limit, no number (the forecaster's own chance of this, stated with the estimate: 80%); the middle value is on the limit's open side.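

No step can be read from compound 2 to compound 3, since each result is a limit of the assay and not a number: the limit of > 24000 nM in this assay, at which 3 of the 3 values shown sit. The compounds shown leave open how toxic any of them is, and whether 3-methyl-1,2-oxazol-5-yl in place of 2-methyl-1,3-thiazol-4-yl changes that toxicity at all.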